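A few compounds are considered here, and "the series" means these few. Any claim that something is new, unique, unknown or untested is made for them only; others in the source may bear on it.

Measured so far:
- compound 1, `Cc1ccc(S(=O)(=O)NCc2cn(C[C@H](O)[C@H]3OC(=O)C(OCc4ccccc4)=C3OCc3ccccc3)nn2)cc1`: 13100 nM
- compound 2, `CCCCCc1ccc(-c2cn(C/C=C3\OC(=O)C(OCc4ccccc4)=C3OCc3ccccc3)nn2)cc1`: > 100000 nM (a limit)
- compound 3, `O=C1O/C(=C\Cn2cc(-c3cc(C(F)(F)F)cc(C(F)(F)F)c3)nn2)C(OCc2ccccc2)=C1OCc1ccccc1`: > 100000 nM (a limit)

For the measured compounds named here, in a functional assay on HCT-116 cells (Homo sapiens) for antiproliferative activity, read by MTT assay, with a stated time of 72 h (a lower number here means a stronger inhibitor, a higher number a weaker inhibitor), compound 1 is the only member with a reported number. For compound 2 the figure is only a limit of the assay. For compound 3 likewise only a limit is reported, (the limit of > 100000 nM in this assay, at which 2 of the 3 values shown sit). Going by the values given here, no two measured compounds differ in one place, so no measured step is available.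

Compound 4, `O=C1O[C@H]([C@@H](O)Cn2cc(CCCCl)nn2)C(OCc2ccccc2)=C1OCc1ccccc1`, keeps the saturated core of compound 1 and is changed at one point: 2-chloroethyl in place of ((4-methylphenyl)sulfonyl)amino on a saturated chain carbon bound to an aromatic carbon. Among the compounds with values here, with no comparable step to lean on, the expectation is a modest loss, of a size near or somewhat beyond the scatter, a 1.9-fold higher number from compound 1 to compound 4 (0.28 log units; within the scatter). Compound 4 is therefore estimated at 25000 nM, within 6000 nM to 100000 nM.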

Compound 4, half-maximal inhibitory concentration: 36100 nM
Compound 4: the middle estimate sits 1.4-fold (0.16 log units) below what was measured; the range from low to high includes it.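

In this assay, the step at this position reads a 2.8-fold higher number from compound 1 to compound 4 (0.44 log units; beyond the scatter) and is modest. On a saturated chain carbon bound to an aromatic carbon, ((4-methylphenyl)sulfonyl)amino with its aromatic ring can give way to 2-chloroethyl, and compound 4 still returns a number rather than a limit. Nothing shown accounts for the size of this step.

Open, from the compounds shown here alone, is whether the chlorine itself matters, which a plain propyl chain would test. Also open, going by these compounds, is how an amine, a carboxylic acid or a longer chain at this place would read.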